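The source may hold more compounds than are shown below. What is called first, only, known or untested is meant among the compounds shown, and "the series" means these compounds.

Measured compounds:
compound 1 `NS(=O)(=O)c1ccc(/N=C2\NC(=O)/C(=C3/C(=O)Nc4ccccc43)S2)cc1` — in a functional assay on MCF7 cells (Homo sapiens) for antiproliferative activity, read by MTT assay (a lower number here means a stronger inhibitor, a higher number a weaker inhibitor), compound 1 gives > 200000 nM, a limit of the assay rather than a number.
compound 2 `NS(=O)(=O)c1ccc(/N=C2\NC(=O)/C(=C3/C(=O)Nc4ccc(Cl)cc43)S2)cc1` — compound 2 gives 3960 nM in this assay.

Compound 2 thus holds the only number shown; the other value is a limit (the limit of > 200000 nM in this assay, at which 1 of the 2 values shown sits). Among the compounds with values here, the one measured step is an at least 50-fold lower number from compound 1 to compound 2 (1.70 log units; beyond the scatter), a large move toward a stronger inhibitor. Compound 3 `COc1ccc2c(c1)/C(=C1/S/C(=N/c3ccc(S(N)(=O)=O)cc3)NC1=O)C(=O)N2` differs from compound 2 by methoxy in place of chloro on an aromatic carbon, at the same aromatic carbon that the measured step altered. Because an at least 50-fold lower number from compound 1 to compound 2 (1.70 log units; beyond the scatter) shows the group at this carbon to matter greatly, the change is unlikely to be neutral, yet methoxy itself has not been tested. Compound 3 is therefore estimated at 12000 nM, within 2500 nM to 60000 nM. This amounts to an expected step of a 3.0-fold higher number from compound 2 to compound 3 (0.48 log units; beyond the scatter) toward a weaker inhibitor.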

Compound 3, half-maximal inhibitory concentration: 125000 nM
Compound 3: middle estimate off by 10-fold (1.02 log units), on the low side; the whole stated range lies below it.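

In this assay, the swap at this aromatic carbon gives a 32-fold higher number from compound 2 to compound 3 (1.50 log units; beyond the scatter), so the gain seen with chloro does not carry over to methoxy. Methoxy in place of hydrogen gives an at least 1.6-fold lower number from compound 1 to compound 3 (0.20 log units; that floor lies within the scatter), so methoxy cannot be separated from hydrogen on these numbers. The value of compound 1 is a limit of the assay, not a number: the limit of > 200000 nM in this assay, at which 1 of the 3 values shown sits.

Going by these compounds, whether the gain belongs to chloro alone or extends to fluoro or bromo at this carbon stays open. So does the outcome with a methyl, an amine or a nitrile there.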